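Aryl sulfone series on the glutamate receptor: fluorophenyl analogue

The source may hold more compounds than are shown below. What is called first, only, known or untested is meant among the compounds shown, and "the series" means these compounds.

Measured so far:
compound 1, `Cc1ccc(S(=O)(=O)c2cnc3cc(F)ccc3c2N2CCC(C)CC2)cc1C`: 90%
compound 2, `CC1CCN(c2c(S(=O)(=O)c3cccc(C#N)c3)cnc3cc(Cl)ccc23)CC1`: 94%

In an assay on isolated protein for displacement of a labelled ligand from metabotropic glutamate receptor 5 (Homo sapiens), with a stated time of 60 min, tested at 1 uM (a higher number here means more inhibition at the concentration tested (going by the name of the read-out), a lower number less inhibition), compound 1 gives 90% and compound 2 gives 94%; the two numbers lie within the scatter of each other, so neither stands apart. Compound 3, `CC1CCN(c2c(S(=O)(=O)c3ccc(F)cc3)cnc3cc(F)ccc23)CC1`, has not been measured. Relative to compound 1 it differs in one place: 4-fluorophenyl in place of 3,4-dimethylphenyl on a sulfonyl sulfur. Since a differently substituted phenyl in compound 2 gives 94%, no step beyond the scatter is expected for this exchange. Compound 3 is estimated at 88%, between 70% and 97%, an expected step of a number 2 percentage points lower from compound 1 to compound 3 (within the scatter).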

Compound 3, a percentage reported as inhibition, at one concentration (the size of the read-out at that concentration, not a potency): 74.5%
The estimate for compound 3 lay 13.5 percentage points above the measured number; low and high end bracket the measured number.
By their numbers in this assay, from the lowest: compound 3; then compounds 1 and 2 (each within the scatter of the next).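

On the sulfonyl sulfur, the aryl group is not freely exchangeable: in this assay, 4-fluorophenyl in place of 3,4-dimethylphenyl gives a number 15.5 percentage points lower from compound 1 to compound 3 (beyond the scatter), with the rest of the structure unchanged. No measurement shown here accounts for this step.

The compounds shown leave open whether the step follows from the loss of the two methyl groups or from the entry of fluorine. A 4-methylphenyl group on the sulfonyl sulfur would help separate the two, while compound 2 differs from both compounds in more than one place and cannot settle this.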